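Changing the aryl group on the ring amine nitrogen

A few compounds are considered here, and "the series" means these few. Any claim that something is new, unique, unknown or untested is made for them only; others in the source may bear on it.

Compound 2 `Nc1scc(CN2CCN(c3ccccc3F)CC2)c1C(=O)c1ccc(Cl)cc1` gives 4% in an assay on CHO cells for displacement of a labelled ligand from adenosine receptor A1 (Homo sapiens), read by scintillation counting, with a stated time of 120 min, tested at 10 uM; on this read-out lower numbers stand for less inhibition and higher numbers for more inhibition at the one concentration tested (going by the name of the read-out). Compound 1 `Nc1scc(CN2CCN(c3ccc(Cl)cc3Cl)CC2)c1C(=O)c1ccc(Cl)cc1` gives 0% in this assay, and the step of a number 4 percentage points higher from compound 1 to compound 2 (within the scatter) leaves the two within the usual scatter, so neither stands apart. Compound 3 `Nc1scc(CN2CCN(c3ccc(Cl)c(Cl)c3)CC2)c1C(=O)c1ccc(Cl)cc1` differs from compound 2 by 3,4-dichlorophenyl in place of 2-fluorophenyl on an amine nitrogen in a ring. Within the data shown here, the one step measured so far also exchanged the aryl group on that ring nitrogen and stayed within the scatter, so no shift beyond the scatter is expected here either: the step of a number 1 percentage points lower from compound 2 to compound 3 (within the scatter) is expected to be small. Compound 3 is therefore estimated at 3%, within -5% to 15%.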

Compound 3, a percentage reported as inhibition, at one concentration (the size of the read-out at that concentration, not a potency): 1%
Compound 3: the middle estimate sits 2 percentage points above what was measured; low and high end bracket the measured number.
By their numbers in this assay, from the lowest: compounds 1, 3 and 2 (each within the scatter of the next).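

In this assay the change to 3,4-dichlorophenyl shows a number 3 percentage points lower from compound 2 to compound 3 (within the scatter) and a number 1 percentage points higher from compound 1 to compound 3 (within the scatter) on the same ring amine nitrogen. This position has now carried three different aryl groups, including two placements of the chlorine pair, and all three numbers stay within the scatter of each other. No available data explain why these numbers stay together.

Still open, going by these compounds, is whether a phenyl ring carrying a methoxy group or a carboxylic acid, or a benzyl group, on this nitrogen would move the number beyond the scatter.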